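This account rests on a few compounds, and the source may have more. Where it says the series, first, only, none or still open, it means among the compounds named here.

In a functional assay on A549 cells (Homo sapiens) for cytotoxicity, read by MTT assay, with a stated time of 48 h (a higher number here means a weaker inhibitor, a lower number a stronger inhibitor), three compounds with a shared core have been measured. Compound 1 `COc1ccc(N/C=C\C(=O)c2nc(-c3ccc(C(F)(F)F)cc3)n3ccccc23)cc1OC` gives > 30000 nM, which is a limit of the assay rather than a number; it sits at the limit of > 30000 nM in this assay, at which 1 of the 3 values shown sits. Compound 2 `O=C(/C=C\Nc1ccc2[nH]ccc2c1)c1nc(-c2ccc(C(F)(F)F)cc2)n2ccccc12` gives 5190 nM. Compound 3 `O=C(/C=C\Nc1ccc(Cl)cc1)c1nc(-c2ccc(C(F)(F)F)cc2)n2ccccc12` gives 18500 nM, the higher of the two numbers that are not limits. The step of a 3.6-fold higher number from compound 2 to compound 3 (0.55 log units; beyond the scatter) separates compound 3 from compound 2, while an at least 5.7-fold lower number from compound 1 to compound 2 (0.76 log units; beyond the scatter) and an at least 1.6-fold lower number from compound 1 to compound 3 (0.20 log units; that floor lies within the scatter) both start from a limit and only set a floor on the change.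

Compound 4 `O=C(/C=C\Nc1cnc2ccccc2c1)c1nc(-c2ccc(C(F)(F)F)cc2)n2ccccc12` differs from compound 3 by quinolin-3-yl in place of 4-chlorophenyl on an amine nitrogen. The measured step that bears on this is a 3.6-fold higher number from compound 2 to compound 3 (0.55 log units; beyond the scatter), read in reverse: there a larger aromatic group on the amine nitrogen was exchanged for 4-chlorophenyl and the number rose. Going back from 4-chlorophenyl to a larger aromatic group, now quinolin-3-yl, is expected to bring the number down again by a modest amount, though the entering group is not the indol-5-yl of compound 2, so the expected step of a 2.5-fold lower number from compound 3 to compound 4 (0.39 log units; beyond the scatter) in this assay is taken as somewhat smaller than that one. Compound 4 is therefore estimated at 7500 nM, with a range from 2500 nM to 22000 nM.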

Compound 4, half-maximal inhibitory concentration: > 30000 nM
Compound 4 ended at the assay's limit; the forecaster's own chance of this, stated with the estimate: 15%; middle value at least 4.0-fold (0.60 log units) away from the limit.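

Compound 4 gives > 30000 nM in this assay, which is a limit of the assay and not a number. The larger aromatic group on the amine nitrogen therefore does not by itself bring the number down: an at least 5.7-fold higher number from compound 2 to compound 4 (0.76 log units; beyond the scatter) shows that quinolin-3-yl and 1H-indol-5-yl are not interchangeable here, even though both are larger than 4-chlorophenyl, while an at least 1.6-fold higher number from compound 3 to compound 4 (0.20 log units; that floor lies within the scatter) leaves quinolin-3-yl not clearly separated from 4-chlorophenyl. Compound 1 and compound 4 now share the upper end of the range, and the step between them cannot be read, so only compound 2 and compound 3 carry numbers that can be compared directly: the limit of > 30000 nM in this assay, at which 2 of the 4 values shown sit.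

The compounds shown leave open whether the ring nitrogen of quinolin-3-yl or the size of the group goes with the loss, a question that a naphthalen-2-yl group on the same amine nitrogen would address. They also leave open whether the 1H-indol-5-yl result depends on its ring nitrogen and the amine hydrogen it carries, which a 1-methylindol-5-yl group would test.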